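The source may report more compounds than this note shows. Statements on the series, on what has been measured and on what is new or still open speak of the compounds shown alone.

Compound 2 `Cc1cn2c(-c3cn[nH]c3)cnc2c(Nc2cc(Cc3ncccn3)ns2)n1` is one of a small set sharing a common core. In an ADME assay on the whole organism for pharmacokinetics, with Rattus norvegicus as the target, with a stated time of 6 h, at a dose of 10 mg/kg by the oral route (on this read-out higher numbers stand for higher exposure at the dose given and lower numbers for lower exposure), compound 2 gives 701 ng.h/mL, the lowest of the two numbers available. Its nearest relative, compound 1 `Cc1cn2c(-c3cn[nH]c3)cnc2c(Nc2cc(Cc3nccs3)ns2)n1`, gives 1540 ng.h/mL in this assay, and the step between them, a 2.2-fold lower number from compound 1 to compound 2 (0.34 log units; beyond the scatter), is beyond the scatter. A third analogue, compound 3 `Cc1cn2c(-c3cn[nH]c3)cnc2c(Nc2cc(Cc3cccnc3)ns2)n1`, is recorded as "not determined" (no result reported) in this assay, with no result reported, so it adds nothing to the comparison.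

The new compound, compound 4 `Cc1cn2c(-c3cn[nH]c3)cnc2c(Nc2cc(Cc3ncccc3F)ns2)n1`, differs from compound 2 in one place: 3-fluoropyridin-2-yl in place of pyrimidin-2-yl on a saturated chain carbon bound to an aromatic carbon. Among the measured compounds shown here, the only measured step, from compound 1 to compound 2, involves a different pair of groups, and no measured pair shows what a 3-fluoropyridin-2-yl group does on this saturated chain carbon. The expectation for compound 4 therefore rests on compound 2 alone, whose value 701 ng.h/mL serves as the anchor, and on the observation that the swap from compound 1 to compound 2 produced only a modest change. Compound 4 is expected to give 900 ng.h/mL in this assay, within a range of 350 ng.h/mL to 2300 ng.h/mL, which amounts to an expected step of a 1.3-fold higher number from compound 2 to compound 4 (0.11 log units; within the scatter), not clearly beyond the scatter in either direction.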

Compound 4, area under the concentration-time curve: 569 ng.h/mL
Estimate against measurement, compound 4: 1.6-fold (0.20 log units) above; the range from low to high includes it.
By their numbers in this assay, from the lowest: compounds 4 and 2 (each within the scatter of the next); then compound 1.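

Putting 3-fluoropyridin-2-yl in place of pyrimidin-2-yl on this saturated chain carbon gives a 1.2-fold lower number from compound 2 to compound 4 (0.09 log units; within the scatter) in this assay and so does not separate the two groups on this read-out. Set against the 1,3-thiazol-2-yl group, the same new group gives a 2.7-fold lower number from compound 1 to compound 4 (0.43 log units; beyond the scatter) and pyrimidin-2-yl gives a 2.2-fold lower number from compound 1 to compound 2 (0.34 log units; beyond the scatter), so compound 1 stands apart from compounds 2 and 4, which remain together. No measurement at hand accounts for these numbers.

The compounds shown leave open what the plain pyridin-2-yl group, without its fluorine, would give at this place, and so what the fluorine itself contributes. They also leave open how an amine, a carboxylic acid or a longer chain would read on this saturated chain carbon.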